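The source may hold more compounds than are shown below. What is called first, only, known or untested is meant among the compounds shown, and "the series" means these compounds.

Measured in a functional assay for inhibition of sodium/hydrogen exchanger (Oryctolagus cuniculus); a lower number here means a stronger inhibitor, a higher number a weaker inhibitor:
compound 1 `CCc1cc(Br)c(S(C)(=O)=O)cc1C(=O)N=C(N)N`: 41 nM
compound 2 `Cc1cc(Sc2ccc(Cl)cc2)c(S(C)(=O)=O)cc1C(=O)N=C(N)N`: 19 nM

Compound 2 holds the lowest of the two numbers; compound 1 stands at a higher number, and that gap lies beyond the scatter. Compound 3 `Cc1cc(Nc2ccccc2)c(S(C)(=O)=O)cc1C(=O)N=C(N)N` differs from compound 2 by anilino in place of (4-chlorophenyl)sulfanyl on an aromatic carbon. Among the compounds with values here, no measured pair here shows a change of this kind, so nothing in the numbers tells its size or direction. In this assay compound 3 is expected to show a moderate step of a 2.4-fold higher number from compound 2 to compound 3 (0.37 log units; beyond the scatter) toward a higher number. Compound 3 is therefore estimated at 45 nM, with a range from 12 nM to 170 nM.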

Compound 3, half-maximal inhibitory concentration: 21 nM
Estimate against measurement, compound 3: 2.1-fold (0.33 log units) above; low and high end bracket the measured number.
By their numbers in this assay, from the lowest: compounds 2, 3 and 1 (each within the scatter of the next, the first and the last beyond it).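

At the aromatic carbon ortho to a methylsulfonyl group, anilino in place of (4-chlorophenyl)sulfanyl gives a 1.1-fold higher number from compound 2 to compound 3 (0.04 log units; within the scatter) in this assay, so the two numbers cannot be told apart. This holds even though the two groups differ in their linking atom, the chlorine and the hydrogen-bond donor count. Nothing given here bears on why they read alike.

Phenylsulfanyl or 4-chloroanilino would separate the linking atom from the chlorine, which change together between compound 2 and compound 3. From the compounds shown here alone, whether a group without an aromatic ring, such as morpholine or methoxy, would read alike remains open.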